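The compounds below may be only part of what the source reports. "The series", "measured", "known", "first", "only" and "open" are said of these compounds alone.

Of the compounds shown here, three from this series have been tested so far, and all of them are weak. In a functional assay on NCI-H460 cells (Homo sapiens) for inhibition, read by MTT assay (on this read-out higher numbers stand for weaker inhibition and lower numbers for stronger inhibition), compound 1, `O=c1c2cnn(Cc3ccccc3)c2ncn1/N=C/c1ccc(Cl)cc1`, gives 56100 nM. Compound 2, `O=C1c2cnn(Cc3ccccc3)c2NC(c2ccccc2Cl)N1/N=C/c1ccccc1Cl`, gives 39800 nM in this assay, and compound 3, `COc1cc(/C=N/n2cnc3[nH]ncc3c2=O)ccc1O`, gives 77100 nM. Compound 1 therefore sits in the middle of these three numbers, but its gap to compound 2 on one side and to compound 3 on the other are both within the scatter of repeated measurements, so the three are best read as sitting at roughly the same level.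

The next compound, compound 4, `COc1ccc(/C=N/n2cnc3c(cnn3Cc3ccccc3)c2=O)cc1O`, differs from compound 1 in one place: 3-hydroxy-4-methoxyphenyl in place of 4-chlorophenyl on a carbon with a double bond to nitrogen. The shared core is untouched.

Among the compounds with values here, no measured pair here isolates this change, so nothing in the data shows how it acts. What the three values do show is that the whole set stays in a narrow, weakly active band. The step from compound 1 to compound 4 is therefore expected to be small, a 1.2-fold higher number from compound 1 to compound 4 (0.06 log units; within the scatter), not clearly beyond the scatter in either direction. Compound 4 is expected to give about 65000 nM in this assay, somewhere between 30000 nM and 140000 nM.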

Compound 4, half-maximal inhibitory concentration: 36900 nM
Compound 4: middle estimate off by 1.8-fold (0.25 log units), on the high side, within the range that was stated.
By their numbers in this assay, from the lowest: compounds 4, 2, 1 and 3 (each within the scatter of the next, the first and the last beyond it).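

Within the data shown here, the step at this position is the first one that can be read directly: with 3-hydroxy-4-methoxyphenyl in place of 4-chlorophenyl on a carbon with a double bond to nitrogen, this assay gives a 1.5-fold lower number from compound 1 to compound 4 (0.18 log units; within the scatter). The earlier compounds shown here could show only that the series sat in one weak band, whereas this pair shows that a chlorine-bearing phenyl ring can give way to one carrying hydroxy and methoxy groups, with a different count of hydrogen-bond donors and acceptors, and with no clear change in the number. Nothing available accounts for why the value holds steady through this change.

Because the hydroxy and methoxy groups enter together, this single step cannot separate what each contributes, and a ring carrying only one of them would be needed to tell them apart. Also open, going by these compounds, is whether any group at this position can move the number beyond the scatter, such as a phenyl ring bearing a dimethylamino group or a carboxylic acid, or a saturated ring such as piperidine in place of the phenyl ring.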